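Thioether in place of aryl ether on the shared core

This account rests on a few compounds, and the source may have more. Where it says the series, first, only, none or still open, it means among the compounds named here.

Three compounds of the series have been run in a functional assay on TK-10 cells (Homo sapiens) for inhibition, read by sulforhodamine B assay, with a stated time of 48 h (on this read-out higher numbers stand for lower toxicity in this test and lower numbers for higher toxicity in this test), so far, and none has given a number. Compound 1 `Nc1cc(N)c2nc(-c3ccccc3)c(Oc3ccc(Cl)c(Cl)c3)nc2c1` reaches only the limit of the test, < 100000 nM. Compound 2 `CCOC(=O)[C@H](CCC(=O)O)NC(=O)c1ccc(Oc2nc3cc(N)cc(N)c3nc2-c2ccccc2)cc1` likewise stops at a limit, < 50200 nM. Compound 3 `CCOC(=O)[C@H](CCC(=O)O)NC(=O)c1ccc(CNc2nc3cc(N)cc(N)c3nc2-c2ccccc2)cc1` also stops at a limit, < 100000 nM. Compound 1 thus stands at the limit of < 100000 nM in this assay, at which 2 of the 3 values shown sit; the remaining value sits at the limit of < 50200 nM in this assay, at which 1 of the 3 values shown sits. For the measured compounds named here, with every result a limit, the set shows only that none of the three is strongly toxic in this test, and no step between two measured compounds can be drawn.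

The next compound, compound 4 `COc1ccc(Sc2nc3cc(N)cc(N)c3nc2-c2ccccc2)cc1`, changes compound 1 by (4-methoxyphenyl)sulfanyl in place of 3,4-dichlorophenoxy on an aromatic carbon. Nothing measured in the series speaks to what this swap does in this assay, so the expectation rests only on the shared core and on the fact that compound 1, compound 2 and compound 3 all sit at a limit. The step from compound 1 to compound 4 is expected to be none beyond the scatter, a step that the limit leaves unreadable from compound 1 to compound 4. Compound 4 is accordingly estimated at 80000 nM in this assay, within 20000 nM to 250000 nM, and a further limit rather than a number is the more likely outcome.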

Compound 4, concentration lethal to 50% of the cells: 72400 nM
For compound 4 the middle estimate is 1.1-fold (0.04 log units) above the measured one, and the stated range covers the measured number.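

For the compounds shown here, compound 1 stands only as a limit in this assay, while compound 4 gives a number, and no step between compound 1 and compound 4 can be read. The compounds shown leave open whether (4-methoxyphenyl)sulfanyl in place of 3,4-dichlorophenoxy on an aromatic carbon shifts the read-out at all, and by how much.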